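Aryl in place of tert-butyl on the shared core

The source may hold more compounds than are shown below. What is called first, only, known or untested is meant among the compounds shown, and "the series" means these compounds.

Measured so far:
compound 1 `COc1ccc(-c2c(C)[nH]c(=O)c3c(N)nn(C)c23)cc1`: 24%
compound 2 `CC(C)(C)c1cc2nn(-c3ccccc3)c(N)c2c(=O)[nH]1`: 6%

In an assay on isolated protein for inhibition of MAP kinase-activated protein kinase 2 (Homo sapiens), read by mobility shift assay, tested at 30 uM (a higher number here means more inhibition at the concentration tested (going by the name of the read-out), a lower number less inhibition), compound 2 stands lowest of the two numbers; compound 1 sits above it by a gap beyond the usual scatter. Compound 3 `COc1ccccc1-c1cc2nn(-c3ccccc3)c(N)c2c(=O)[nH]1` is not yet measured. It differs from compound 2 by 2-methoxyphenyl in place of tert-butyl on an aromatic carbon. For the measured compounds named here, no step between measured compounds covers this change, so its size is open. A modest rise is expected because compound 1 gives 24% with a six-membered aromatic ring in the corresponding region of its core. The expected step is a number 10 percentage points higher from compound 2 to compound 3 (within the scatter). Compound 3 is estimated at 16%, within 2% to 35%.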

Compound 3, a percentage reported as inhibition, at one concentration (the size of the read-out at that concentration, not a potency): -1%
Compound 3: middle estimate off by 17 percentage points, on the high side; measured number below the stated range.
By their numbers in this assay, from the lowest: compounds 3 and 2 (each within the scatter of the next); then compound 1.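

In this assay the swap of tert-butyl for 2-methoxyphenyl on the aromatic carbon next to the ring nitrogen gives a number 7 percentage points lower from compound 2 to compound 3 (within the scatter) and so does not separate the two groups. At this position, on this core, a six-membered aromatic ring carrying a methoxy oxygen therefore reads the same as a tert-butyl group within the scatter. Nothing at hand bears on why this step is so small.

As far as these compounds go, whether an amine or a carboxylic acid on this carbon would move the read-out remains open. The gap to compound 1 cannot be assigned to any single place, since that compound differs from the others in more than one.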